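Amino to Methoxy on a Shared Core in Dogs

The source may hold more compounds than are shown below. What is called first, only, known or untested is meant among the compounds shown, and "the series" means these compounds.

Of the compounds shown here, three built on one core have been measured in a functional assay on the whole organism with Canis familiaris (Canis lupus familiaris) as the target, at a dose of 2 mg/kg by the intravenous route; a higher number here means a stronger effect of the compound at the dose given, a lower number a weaker effect. Compound 1 `Cc1nc2c(OCc3ccccc3)cccn2c1N` gives 97%, compound 2 `Cc1nc2c(OCc3ccsc3)cccn2c1N` gives 82%, and compound 3 `Cc1nc2c(CCc3ccccc3)cccn2c1N` gives 71%. Compound 3 stands lowest of the three numbers, with compound 2 nearest and compound 1 furthest. For the measured compounds named here, the only single-point step among the measured compounds is a number 15 percentage points lower from compound 1 to compound 2 (beyond the scatter), a modest lowering.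

Compound 4 `COc1c(C)nc2c(CCc3ccccc3)cccn12` has not yet been measured. It differs from compound 3 in one place: methoxy in place of amino on an aromatic carbon. Going by the values given here, no measured step touches this site on the core; the single step known, from compound 1 to compound 2, concerns the group bound through oxygen on the other ring and says nothing about the amino group. Among the compounds with values here, the expectation for compound 4 therefore rests on no direct precedent and is held loosely. Going by these compounds, the amino group is shared by all three measured compounds, so its removal is untested ground, and a lowering in this assay of uncertain size is the cautious expectation. Compound 4 is estimated at 45%, within 10% to 80%, a step of a number 26 percentage points lower from compound 3 to compound 4 (beyond the scatter) expected from its parent.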

Compound 4, a percentage reported as inhibition, in the whole organism at one dose (the size of the read-out at that dose, not a potency): 0%
Beside the measured number, compound 4's estimate is 45 percentage points above it; measured number below the stated range.
By their numbers in this assay, from the lowest: compound 4; then compound 3; then compound 2; then compound 1.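

At this position on the five-membered aromatic ring, the amino group proves close to decisive in this assay: the change to methoxy gives a number 71 percentage points lower from compound 3 to compound 4 (beyond the scatter) and leaves compound 4 at 0% at the dose given, whereas the change on the other ring gave only a number 15 percentage points lower from compound 1 to compound 2 (beyond the scatter) and left compound 2 at 82%. The earlier compounds shown here all carried the amino group, so they could not show that the effect depends on what sits on this aromatic carbon; this step shows that a single replacement here, with no other change to compound 3, is enough to bring compound 4 to 0%. Counted across the change, amino's hydrogen-bond donor leaves, the hydrogen-bond acceptor count stays the same and the heavy atoms rise, but nothing shown here bears on which of these differences, if any, accounts for the result.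

The compounds shown leave open whether a methylamino, hydroxyl or acetamido group on this carbon would keep any of the effect, which would help separate what amino itself contributes. They also leave open whether methoxy would cost as much on the core of compound 1, which carries benzyl bound through oxygen on the other ring.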